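Swapping a Side Group at the Assay Limit

A few compounds are considered here, and "the series" means these few. Any claim that something is new, unique, unknown or untested is made for them only; others in the source may bear on it.

This series is tested in a functional assay on B16 cells (Mus musculus) for inhibition (on this read-out lower numbers stand for stronger inhibition and higher numbers for weaker inhibition), where cells are exposed to each compound and the concentration giving half-maximal inhibition is read. In this assay, compound 1 (`CC(C)CN(NC(=O)OCc1ccccc1)C(=O)CN(Cc1ccccc1)NC(=O)Cc1cccc(Br)c1`) gives > 80000 nM, which is a limit of the assay and not a number. Compound 2 (`CC(C)CN(CC(=O)NN(Cc1ccccc1)c1cnccn1)NC(=O)Cc1cccc(Br)c1`) gives 23400 nM. Compound 3 (`CC(C)CN(CC(=O)N(CC(C)C)NC(=O)OCc1ccccc1)/N=C/c1cccc(B(O)O)c1`), which carries boron, gives 53900 nM.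

Compound 4 (`CC(C)CN(NC(=O)OCc1ccccc1)C(=O)CN(Cc1ccccc1)/N=C/c1ccc(B(O)O)cc1`) has not been measured yet. Its change from compound 1 is a group of 11 heavy atoms (7 carbon, 1 boron, 1 nitrogen, 2 oxygen; one six-membered aromatic ring of carbon only) in place of a group of 11 heavy atoms (8 carbon, 1 nitrogen, 1 oxygen, 1 bromine; one six-membered aromatic ring of carbon only), on an amine nitrogen. The entering group also holds boron. Among the measured compounds shown here, no measured pair isolates this swap, so the expectation is only rough. For the measured compounds named here, it leans on compound 3 at 53900 nM, the one measured compound with boron, and points to a modest gain in inhibition. The expected change is an at least 1.7-fold lower number from compound 1 to compound 4 (0.24 log units; that floor lies within the scatter), and this size is an estimate. For compound 4 the estimated value is 45000 nM, with an expected range from 15000 nM to 90000 nM.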

Compound 4, half-maximal inhibitory concentration: 32600 nM
Compound 4: middle estimate off by 1.4-fold (0.14 log units), on the high side, within the range that was stated.
By their numbers in this assay, from the lowest: compounds 2, 4 and 3 (each within the scatter of the next, the first and the last beyond it). At a limit, above all of these: compound 1.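

Among the compounds shown here, on the amine nitrogen of the core of compound 1, this swap gives the first step in this assay that can be read between two compounds differing in one place: an at least 2.4-fold lower number from compound 1 to compound 4 (0.38 log units; beyond the scatter). It shows that the group at this place can move the read-out beyond the scatter, and that a group holding boron can take the place of one holding bromine with a measurable number as the result. The step can only be given as a floor, since compound 1 is at a limit of the assay: the limit of > 80000 nM in this assay, at which 1 of the 4 values shown sits.

Bromine leaves and boron enters in one swap, and other atoms change with them, which leaves open how much of the step belongs to the boron itself; the same group with a carboxylic acid in place of the boron and its oxygens would bear on this. As far as these compounds go, how a small group such as a methyl on this amine nitrogen would read also remains open.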